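The compounds below may be only part of what the source reports. "The series", "measured", "known", "first", "only" and "open" are said of these compounds alone.

Two sulfonamides have been measured so far in a functional assay on aorta (Cavia porcellus) for inhibition; a lower number here means a stronger inhibitor, a higher number a weaker inhibitor. There, compound 1 `C=CCN(c1ccccc1)S(=O)(=O)c1ccc(Cl)cc1` gives 17700 nM, while compound 2 `O=S(=O)(c1ccc(Cl)cc1)N1CCC[C@H]1c1cccs1` gives 5160 nM. Compound 2 therefore has the lower number of the two and is the stronger inhibitor, with a gap that lies beyond the usual scatter. The two compounds differ in more than one place, so this gap says nothing about any single structural feature.

The next compound to be tested is compound 3 `O=S(=O)(c1ccc(Cl)cc1)N1CCCC1c1cccs1`, and the change from compound 2 is the two compounds have the same atoms and bonds; at least one stereo element is drawn with a configuration in one of them and without one in the other: 1 of 1 stereo elements differ; a stereocentre at a saturated ring carbon is drawn S in compound 2 and without a configuration in compound 3. The two compounds have the same atoms and bonds, and a stereocentre at a saturated ring carbon is drawn S in compound 2 and without a configuration in compound 3. Among the measured compounds shown here, no measured pair shows how much a drawn configuration matters in this assay, so the expectation rests on compound 2 and its 5160 nM. Only a slight rise in the number is anticipated, with no change beyond the scatter. The expected size of the move is a 1.2-fold higher number from compound 2 to compound 3 (0.07 log units; within the scatter). The estimated value for compound 3 is 6000 nM, within an expected range of 2700 nM to 12000 nM.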

Compound 3, half-maximal inhibitory concentration: 5620 nM
The estimate for compound 3 lay 1.1-fold (0.03 log units) above the measured number; the measured number falls inside the stated range.
By their numbers in this assay, from the lowest: compounds 2 and 3 (each within the scatter of the next); then compound 1.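

In this assay, among the compounds shown here, the step of a 1.1-fold higher number from compound 2 to compound 3 (0.04 log units; within the scatter) gives the first reading of how much a drawn configuration matters at this saturated ring carbon, and it lies within the scatter. Whether this carbon is drawn S, as in compound 2, or without a configuration, as in compound 3, therefore makes no difference that this assay can resolve, a point the gap to compound 1 could not address because that comparison spans more than one place. The reading is a narrow one, since the pair isolates a single feature and nothing else separates the two structures: the fact that one of compounds 2 and 3 is drawn with a defined configuration and the other without, at the place where they differ

On these data alone, what remains open is what the drawing of compound 3 stands for, since the data do not say whether it holds one form or a mixture of both, so the number for the pure R form cannot be worked out from this pair, and a sharper preference for one form cannot be ruled out. Also open, as far as these compounds go, is how the number would respond to a new group on the shared core, such as an amine or a carboxylic acid.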